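Fluorine added to the sulfonamide aryl of compound 1

A few compounds are considered here, and "the series" means these few. Any claim that something is new, unique, unknown or untested is made for them only; others in the source may bear on it.

Measured compounds:
compound 1 `O=C1O[C@H]([C@@H](O)Cn2cc(CNS(=O)(=O)c3ccc(Cl)cc3)nn2)C(OCc2ccccc2)=C1OCc1ccccc1`: 4170 nM
compound 2 `COc1ccc(-c2cn(C[C@H](O)[C@H]3OC(=O)C(OCc4ccccc4)=C3OCc3ccccc3)nn2)cc1`: 99700 nM

Of the compounds shown here, two have been tested in a functional assay on MCF7 cells (Homo sapiens) for antiproliferative activity, read by MTT assay, with a stated time of 72 h; a lower number here means a stronger inhibitor, a higher number a weaker inhibitor. Compound 1 `O=C1O[C@H]([C@@H](O)Cn2cc(CNS(=O)(=O)c3ccc(Cl)cc3)nn2)C(OCc2ccccc2)=C1OCc1ccccc1` gives 4170 nM and carries the lowest number of the two. Within the data shown here, compound 2 `COc1ccc(-c2cn(C[C@H](O)[C@H]3OC(=O)C(OCc4ccccc4)=C3OCc3ccccc3)nn2)cc1` gives 99700 nM in this assay, and the single measured step is a 24-fold higher number from compound 1 to compound 2 (1.38 log units; beyond the scatter), a swap of the whole side group on the triazole.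

Compound 3 `O=C1O[C@H]([C@@H](O)Cn2cc(CNS(=O)(=O)c3ccc(Cl)cc3F)nn2)C(OCc2ccccc2)=C1OCc1ccccc1` is not yet measured. It differs from compound 1 by fluoro in place of hydrogen on an aromatic carbon. Among the measured compounds shown here, no measured step concerns an added halogen on this aryl ring; the one known step changes a different part of the molecule and is therefore of little use as a guide here. With the sulfonamide itself retained, compound 3 is expected to stay close to compound 1, the step of a 1.2-fold lower number from compound 1 to compound 3 (0.08 log units; within the scatter) being estimated to lie within the scatter of repeated measurements. On this basis compound 3 is estimated at 3500 nM in this assay, within a range of 1500 nM to 9000 nM.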

Compound 3, half-maximal inhibitory concentration: 3390 nM
Estimate against measurement, compound 3: 1.0-fold (0.01 log units) above; the range from low to high includes it.
By their numbers in this assay, from the lowest: compounds 3 and 1 (each within the scatter of the next); then compound 2.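

In this assay, fluoro in place of hydrogen on the aromatic ring of the sulfonamide, ortho to a large group and meta to the chloro group, gives a 1.2-fold lower number from compound 1 to compound 3 (0.09 log units; within the scatter). Among these compounds, this is the first reading at this place on the ring, and it shows that adding this one atom leaves the number within the scatter, so the 4-chloro-2-fluorophenyl and 4-chlorophenyl groups cannot be told apart here, whereas exchanging the whole side group for 4-methoxyphenyl gave a 24-fold higher number from compound 1 to compound 2 (1.38 log units; beyond the scatter). Nothing at hand bears on why the added fluoro leaves the reading unresolved from that of compound 1.

The compounds shown leave open whether this place on the ring would accept something larger than fluoro, such as a methoxy group, a trifluoromethyl group or an amine, with as little effect on the number. They also leave open what happens when the chloro group itself is exchanged, for instance for a nitrile or a carboxylic acid, or when the sulfonyl group is replaced by a carbonyl while the rest of compound 1 stays the same.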